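Replacing tert-butyl with cyano in the series

The compounds below may be only part of what the source reports. "The series", "measured", "known", "first", "only" and "open" are said of these compounds alone.

In an ADME assay on U2OS cells (Homo sapiens) for cytotoxicity (a lower number here means that less compound is tolerated, a higher number that more compound is tolerated), compound 1 `CC(C)(C)c1ccc(C(=O)N/N=C/c2ccc([N+](=O)[O-])o2)cc1` gives > 200000 nM, which is a limit of the assay and not a number. Compound 1 therefore stands at the limit of > 200000 nM in this assay, at which 1 of the 3 values shown sits.

The two other measured compounds give numbers. Compound 2 `CCCCc1ccc(C(=O)N/N=C/c2ccc([N+](=O)[O-])o2)cc1` gives 19600 nM, and compound 3 `O=C(N/N=C/c1ccc([N+](=O)[O-])o1)c1ccc2ccccc2c1` gives 64200 nM.

The next compound to be measured is compound 4 `N#Cc1ccc(C(=O)N/N=C/c2ccc([N+](=O)[O-])o2)cc1`, which has cyano in place of tert-butyl on an aromatic carbon.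

For the measured compounds named here, only one measured step replaces the tert-butyl group of compound 1. This is an at least 10-fold lower number from compound 1 to compound 2 (1.00 log units; beyond the scatter), with butyl in place of tert-butyl. As far as these compounds go, since compound 1 has only a limit, the true size of that step remains open. Going by the values given here, no measured compound carries cyano, so the evidence for the new group is thin.

The direction is taken from compound 2, and the numbers of compound 2 and compound 3 serve as a guide to the likely level in this assay. A lower number, beyond the scatter, is expected, and the estimated change is an at least 3.3-fold lower number from compound 1 to compound 4 (0.52 log units; beyond the scatter).

The estimate for compound 4 is 60000 nM, with an expected range of 15000 nM to 200000 nM.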

Compound 4, half-maximal cytotoxic concentration: 21400 nM
The estimate for compound 4 lay 2.8-fold (0.45 log units) above the measured number; the range from low to high includes it.
By their numbers in this assay, from the lowest: compounds 2 and 4 (each within the scatter of the next); then compound 3. At a limit, above all of these: compound 1.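

With cyano, a second replacement of tert-butyl on this aromatic carbon, para to a large group, is on record in this assay: it gives an at least 9.3-fold lower number from compound 1 to compound 4 (0.97 log units; beyond the scatter), in the same direction as an at least 10-fold lower number from compound 1 to compound 2 (1.00 log units; beyond the scatter). The two replacements cannot be told apart, with cyano in place of butyl giving a 1.1-fold higher number from compound 2 to compound 4 (0.04 log units; within the scatter), so a nitrile and a straight chain stand level here, and among compounds 1, 2 and 4 only the tert-butyl compound stands apart. The result for compound 1 is a limit of the assay and not a number, so the full size of both steps away from it stays open: the limit of > 200000 nM in this assay, at which 1 of the 4 values shown sits.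

As far as these compounds go, whether the separation belongs to tert-butyl alone or extends to other branched groups remains open, and isopropyl or cyclopropyl at this position would test that. From the compounds shown here alone, it is equally open whether the level shared by compound 2 and compound 4 holds for quite different groups, such as an amine, a carboxylic acid or a longer chain, or for the same groups placed elsewhere on the ring.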